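The source may hold more compounds than are shown below. What is called first, only, known or untested is meant among the compounds shown, and "the series" means these compounds.

Working notes on the series. Compounds 1, 2 and 3 share one core and differ only in the group on the oxygen on a saturated carbon. In an assay on DDT1 cells (Cricetulus griseus) for binding affinity to adenosine receptor A1 (Homo sapiens), read by radioligand binding (a higher number here means a weaker inhibitor, a lower number a stronger inhibitor), compound 1 `C/N=C(\S)OC[C@H]1OC(n2cnc3c(NC4CCOC4)ncnc32)[C@H](O)[C@@H]1O` gives 45 nM, compound 2 `CC(C)NC(=O)OC[C@H]1OC(n2cnc3c(NC4CCOC4)ncnc32)[C@H](O)[C@@H]1O` gives 78 nM, and compound 3 `O[C@@H]1[C@@H](CO/C(S)=N/C2CC2)OC(n2cnc3c(NC4CCOC4)ncnc32)[C@@H]1O` gives 157 nM. Among the compounds with values here, compound 3 stands at the highest number of the three, but the step of a 2.0-fold higher number from compound 2 to compound 3 (0.30 log units; within the scatter) lies within the scatter, so only the step of a 3.5-fold higher number from compound 1 to compound 3 (0.54 log units; beyond the scatter) separates it clearly from another member.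

Compound 4 `O=C(NCc1ccccc1)OC[C@H]1OC(n2cnc3c(NC4CCOC4)ncnc32)[C@H](O)[C@@H]1O` carries the change (a group of 10 heavy atoms (8 carbon, 1 nitrogen, 1 oxygen; one six-membered aromatic ring of carbon only) in place of a group of 6 heavy atoms (4 carbon, 1 nitrogen, 1 sulfur; one three-membered non-aromatic ring of carbon only), on an oxygen on a saturated carbon). Within the data shown here, two measured steps bear on this kind of swap at the same place: a 1.7-fold higher number from compound 1 to compound 2 (0.24 log units; within the scatter) and a 2.0-fold higher number from compound 2 to compound 3 (0.30 log units; within the scatter), both within the scatter, so exchanges of the group on that oxygen have so far moved the number little. Compound 4 also shares the carbamate-type linkage of compound 2, whose value 78 nM sits close to compound 3. For compound 4 the expected step is therefore a 1.7-fold lower number from compound 3 to compound 4 (0.24 log units; within the scatter), with no clear direction beyond the scatter. The estimate for compound 4 in this assay is 90 nM, in the range 30 nM to 300 nM.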

Compound 4, inhibition constant: 1830 nM
Estimate against measurement, compound 4: 20-fold (1.31 log units) below; the whole stated range lies below it.
By their numbers in this assay, from the lowest: compounds 1, 2 and 3 (each within the scatter of the next, the first and the last beyond it); then compound 4.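

In this assay, within the data shown here, the group on the oxygen on a saturated carbon proves far less tolerant of exchange than the earlier compounds suggested: with only benzyl in place of isopropyl on an amide-type nitrogen, the step is a 23-fold higher number from compound 2 to compound 4 (1.37 log units; beyond the scatter). Benzylcarbamoyl also separates compound 4 from the other two members, with a 12-fold higher number from compound 3 to compound 4 (1.07 log units; beyond the scatter) and a 41-fold higher number from compound 1 to compound 4 (1.61 log units; beyond the scatter), so the linkage shared with compound 2 does not keep the number close to that of compound 2. No measurement shown accounts for this loss.

The compounds shown leave open whether the step follows the aromatic ring itself or the group of 10 heavy atoms as a whole. A cyclohexylmethyl group on the amide-type nitrogen would separate these two readings, and a phenyl group there would test the chain carbon that links benzyl to that nitrogen.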